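Fluoro in Place of Methyl on a Fused Core

A few compounds are considered here, and "the series" means these few. Any claim that something is new, unique, unknown or untested is made for them only; others in the source may bear on it.

Measured so far:
compound 1 `Cc1cc(C)c2c(c1)C(c1ccc(O)cc1)(C1CCCCCC1)C(=O)N2` — > 1000 nM
compound 2 `Cc1cc(F)cc2c1NC(=O)C2(c1ccc(O)cc1)C1CCCCCC1` — > 1000 nM
compound 3 `Cc1ccc2c(c1C)NC(=O)C2(c1ccc(O)cc1)C1CCCCCC1` — 19 nM

All three were tested in a functional assay on MCF7 cells (Homo sapiens) for cytotoxicity, read by WST assay, with a stated time of 72 h; on this read-out lower numbers stand for stronger inhibition and higher numbers for weaker inhibition. For compound 1 the value is a limit of the assay, not a number. For compound 2 the value is likewise a limit. Among the measured compounds shown here, compound 3 is the only one with a true number. The change from compound 1 to compound 2 is fluoro in place of methyl on an aromatic carbon, and its step is a step that the two limits leave unreadable from compound 1 to compound 2; it is unreadable because of the limit of > 1000 nM in this assay, at which 2 of the 3 values shown sit. How the core of compound 1 and the core of compound 3 differ is not broken down here.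

Compound 4 `Cc1c(F)ccc2c1NC(=O)C2(c1ccc(O)cc1)C1CCCCCC1` is not yet measured. It differs from compound 3 by fluoro in place of methyl on an aromatic carbon, the same kind of change as that from compound 1 to compound 2, but the surroundings differ: here the place is ortho to a methyl group, whereas before it was meta to a methyl group. For the measured compounds named here, the one measured instance gives no readable size, so the expectation rests mainly on compound 3 with 19 nM. Compound 4 is expected to give about 60 nM, estimated between 15 nM and 400 nM. The expected step is a 3.2-fold higher number from compound 3 to compound 4 (0.50 log units; beyond the scatter).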

Compound 4, half-maximal inhibitory concentration: 20 nM
Compound 4: middle estimate off by 3.0-fold (0.48 log units), on the high side, and the stated range covers the measured number.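

In this assay, fluoro in place of methyl on the core of compound 3 gives a 1.1-fold higher number from compound 3 to compound 4 (0.02 log units; within the scatter), so on this core, at this place ortho to a methyl group, the read-out does not tell the two groups apart. The earlier instance of the same change offers no size to set beside this one, because the step between its two compounds cannot be read: the limit of > 1000 nM in this assay, at which 2 of the 4 values shown sit. The result therefore shows the change on one core only; it does not show that the change would behave the same way on the core of compound 1, where its surroundings differ, and a single readable pair sets no rule for the series.

The compounds shown leave open what other groups at this place would do, such as chloro, an amine or a carboxylic acid. Also open, going by these compounds, is whether the result would hold if the remaining methyl group were changed as well, for example to an ethyl group.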